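A Pyridine Ring Replaces the Dimethylaminophenyl Group

This account rests on a few compounds, and the source may have more. Where it says the series, first, only, none or still open, it means among the compounds named here.

Three compounds share one core and differ only in the aromatic ring attached to the carbonyl carbon of the piperidine amide. In an assay on U2OS cells for inhibition of secreted frizzled-related protein 1 (Homo sapiens), read by a luciferase reporter, with a stated time of 18 h (a lower number here means that less compound is needed, a higher number that more compound is needed for the effect), compound 1 `O=C(c1ccccc1)N1CCC(NS(=O)(=O)c2cc(S(=O)(=O)c3ccccc3)ccc2C(F)(F)F)CC1` gives 250 nM; compound 2 `O=C(c1cccc(Cl)c1)N1CCC(NS(=O)(=O)c2cc(S(=O)(=O)c3ccccc3)ccc2C(F)(F)F)CC1` gives 870 nM; compound 3 `CN(C)c1ccc(C(=O)N2CCC(NS(=O)(=O)c3cc(S(=O)(=O)c4ccccc4)ccc3C(F)(F)F)CC2)cc1` gives 190 nM. Compound 3 shows the lowest number of the three, though the gap to compound 1 is within the scatter, as seen in a 1.3-fold lower number from compound 1 to compound 3 (0.12 log units; within the scatter). The step of a 4.6-fold lower number from compound 2 to compound 3 (0.66 log units; beyond the scatter) lies beyond the scatter, as does a 3.5-fold higher number from compound 1 to compound 2 (0.54 log units; beyond the scatter).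

Compound 4 `O=C(c1cccnc1)N1CCC(NS(=O)(=O)c2cc(S(=O)(=O)c3ccccc3)ccc2C(F)(F)F)CC1` is not yet measured. Its difference from compound 3 is pyridin-3-yl in place of 4-(dimethylamino)phenyl on a carbonyl carbon. The measured steps show that a change on this ring can move the number beyond the scatter, as with a 3.5-fold higher number from compound 1 to compound 2 (0.54 log units; beyond the scatter), or leave it essentially unchanged, as with a 1.3-fold lower number from compound 1 to compound 3 (0.12 log units; within the scatter). Compound 4 carries no substituent on its ring, so it resembles compound 1 most closely in this position, and the number is expected to fall between those of compound 1 and compound 2. The expected step is a 1.8-fold higher number from compound 3 to compound 4 (0.27 log units; within the scatter), a rise that might or might not exceed the scatter. Compound 4 is therefore estimated at 350 nM, with a range from 120 nM to 1000 nM.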

Compound 4, half-maximal effective concentration: 120 nM
Compound 4: the middle estimate sits 2.9-fold (0.46 log units) above what was measured; low and high end bracket the measured number.
By their numbers in this assay, from the lowest: compounds 4, 3 and 1 (each within the scatter of the next, the first and the last beyond it); then compound 2.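

Within the data shown here, replacing one ring carbon of the phenyl group with a ring nitrogen gives a 2.1-fold lower number from compound 1 to compound 4 (0.32 log units; beyond the scatter) and is the first change on this ring to lower the number beyond the scatter, whereas adding dimethylamino to the phenyl ring did not do so. In this assay the unsubstituted pyridin-3-yl ring also stays level with 4-(dimethylamino)phenyl, with a 1.6-fold lower number from compound 3 to compound 4 (0.20 log units; within the scatter) so a number in this range does not depend on carrying that substituent, while the gap to the chlorinated ring grows to a 7.3-fold lower number from compound 2 to compound 4 (0.86 log units; beyond the scatter) and is the widest step among these compounds. The data at hand offer no explanation for why this ring nitrogen lowers the number.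

On these data alone, it remains open whether the location of the ring nitrogen matters, which pyridin-2-yl and pyridin-4-yl rings could test, and whether a dimethylamino or chloro group on the pyridine ring would move the number as those groups do on the phenyl ring. Also open, as far as these compounds go, is how this ring change would combine with changes elsewhere in the shared core, such as a nitrile or a methyl group in place of the trifluoromethyl group.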